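Notes on an aryl swap at the saturated ring carbon

This account rests on a few compounds, and the source may have more. Where it says the series, first, only, none or still open, it means among the compounds named here.

Compound 1 `N#CC1=C(N)N(c2ccc(S(N)(=O)=O)cc2)C2=C(CCCC2)C1c1ccc(O)cc1`: 42%
Compound 2 `N#CC1=C(N)N(c2ccc(S(N)(=O)=O)cc2)C2=C(CCCC2)C1c1ccccc1Cl`: 0%

Within the data shown here, in a functional assay on Ehrlich cells (Mus musculus) for cytotoxicity, read by trypan blue exclusion, with a stated time of 2 h, tested at 25 ug/mL (on this read-out higher numbers stand for a stronger effect at the one concentration tested and lower numbers for a weaker effect), compound 1 gives 42%, the highest of the two numbers measured so far. Compound 2 gives 0%. Among the measured compounds shown here, the only step between measured compounds is a number 42 percentage points lower from compound 1 to compound 2 (beyond the scatter), an exchange of the 4-hydroxyphenyl for 2-chlorophenyl on a saturated ring carbon.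

Compound 3 `Cc1ccc(C2C(C#N)=C(N)N(c3ccc(S(N)(=O)=O)cc3)C3=C2CCCC3)o1` is not yet measured. It differs from compound 1 by 5-methylfuran-2-yl in place of 4-hydroxyphenyl on a saturated ring carbon. The group that enters carries 0 hydrogen-bond donors where 4-hydroxyphenyl carried 1, and the measured step bears on it in that both changes replace the 4-hydroxyphenyl with another aromatic group at the same saturated ring carbon. Because a number 42 percentage points lower from compound 1 to compound 2 (beyond the scatter) was large and beyond the scatter, a fall in this assay is expected for compound 3 as well, though with a single supporting step and a different entering group the size is uncertain. The expected step is a number 27 percentage points lower from compound 1 to compound 3 (beyond the scatter). Compound 3 is therefore estimated at 15%, within a range from 0% to 40%.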

Compound 3, a percentage reported as activity, at one concentration (the size of the read-out at that concentration, not a potency): 10%
Compound 3: middle estimate off by 5 percentage points, on the high side; the measured number falls inside the stated range.
By their numbers in this assay, from the lowest: compounds 2 and 3 (each within the scatter of the next); then compound 1.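

In this assay, a second replacement of the 4-hydroxyphenyl on the saturated ring carbon gives a number 32 percentage points lower from compound 1 to compound 3 (beyond the scatter) and so the large fall is not tied to the 2-chlorophenyl alone; of the three compounds, only compound 1, the one that holds the 4-hydroxyphenyl, stands apart. The two entering groups cannot be told apart here, with a number 10 percentage points higher from compound 2 to compound 3 (within the scatter) even though one is a six-membered aromatic ring of carbon only and the other a five-membered aromatic ring with 1 hetero atom. Nothing on hand explains the fall at this position.

The compounds shown leave open whether the activity of compound 1 depends on the hydroxyl of the 4-hydroxyphenyl or on the substituted ring as a whole, a question that an unsubstituted phenyl or a methoxy-bearing phenyl on the same saturated ring carbon would address. They also leave open how the read-out behaves at other concentrations and whether a change elsewhere on the core of compound 1, such as at the 4-sulfamoylphenyl group, would move it.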